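The source may report more compounds than this note shows. Statements on the series, on what has been measured and on what is new or still open speak of the compounds shown alone.

Compound 1 `O=C(/C=C\Nc1ccc(O)cc1)c1cn(-c2ccccc2)nc1-c1ccccc1` and compound 2 `COc1ccc(-c2nn(-c3ccccc3)cc2C(=O)/C=C\Nc2ccc(Cl)cc2)cc1` both give numbers in a functional assay on A549 cells (Homo sapiens) for antiproliferative activity, read by MTT assay, with a stated time of 48 h; a lower number here means a stronger inhibitor, a higher number a weaker inhibitor: compound 1 gives 3210 nM and compound 2 gives 2970 nM. Compound 3 `COc1ccc(-c2nn(-c3ccccc3)cc2C(=O)/C=C\Nc2ccc(C(F)(F)F)cc2)cc1` is reported only as a limit of this assay, > 50000 nM, the point at which one of the three known values sits (the limit of > 50000 nM in this assay, at which 1 of the 3 values shown sits). Among the measured compounds shown here, the single known step, an at least 16-fold higher number from compound 2 to compound 3 (1.22 log units; beyond the scatter), is the only guide. Compound 4 `COc1ccc(-c2nn(-c3ccccc3)cc2C(=O)/C=C\Nc2ccc(O)cc2)cc1` differs from compound 3 by hydroxy in place of trifluoromethyl on an aromatic carbon. Since the hydroxy-bearing compound 1 already gives a number, a large drop toward a measurable value is expected, an at least 16-fold lower number from compound 3 to compound 4 (1.22 log units; beyond the scatter), in this assay. Compound 4 is estimated at 3000 nM, plausibly between 1000 nM and 15000 nM.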

Compound 4, half-maximal inhibitory concentration: 2770 nM
For compound 4 the middle estimate is 1.1-fold (0.03 log units) above the measured one; measured number inside the range.
By their numbers in this assay, from the lowest: compounds 4, 2 and 1 (each within the scatter of the next). At a limit, above all of these: compound 3.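

In this assay, the 4-hydroxyphenyl group gives a measurable value where 4-(trifluoromethyl)phenyl gave none (an at least 18-fold lower number from compound 3 to compound 4 (1.25 log units; beyond the scatter)). That step starts from compound 3, whose entry is a limit and not a number: (the limit of > 50000 nM in this assay, at which 1 of the 4 values shown sits). Hydroxy and chloro at this position are not told apart (a 1.1-fold lower number from compound 2 to compound 4 (0.03 log units; within the scatter)), nor is methoxy in place of hydrogen on an aromatic carbon (a 1.2-fold lower number from compound 1 to compound 4 (0.06 log units; within the scatter)), so among these compounds only trifluoromethyl stands apart.

From the compounds shown here alone, whether an amine, a carboxylic acid or a methoxy group at this position would stay level with compound 4 remains open. So does whether trifluoromethyl would give the same large step on the core of compound 1.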